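A few compounds are considered here, and "the series" means these few. Any claim that something is new, unique, unknown or untested is made for them only; others in the source may bear on it.

- Compound 1 `COc1ccc(CN(C(=O)CSC2=CN=NC2C)c2cc(OC)c(OC)c(OC)c2)cc1`: 2960 nM
- Compound 2 `COc1ccc(CN(C(=O)CSc2nncs2)c2cc(OC)c(OC)c(OC)c2)cc1`: 1150 nM

In a functional assay on MGC-803 cells (Homo sapiens) for antiproliferative activity, read by MTT assay, with a stated time of 48 h (on this read-out lower numbers stand for stronger inhibition and higher numbers for weaker inhibition), compound 2 gives the lower of the two numbers, 1150 nM. Compound 3 `COc1ccc(CN(C(=O)CSc2nc3ccccc3[nH]2)c2cc(OC)c(OC)c(OC)c2)cc1` differs from it on the sulfur: 1H-benzimidazol-2-yl in place of 1,3,4-thiadiazol-2-yl on a sulfur. Among the measured compounds shown here, one measured step bears on this, also a change of group on that sulfur: a 2.6-fold lower number from compound 1 to compound 2 (0.41 log units; beyond the scatter). This modest step is a single precedent and does not fix a direction, so no change beyond the scatter is expected in this assay. The expected step is a 1.2-fold lower number from compound 2 to compound 3 (0.06 log units; within the scatter). For compound 3 the estimate is 1000 nM, with an expected range of 250 nM to 4000 nM.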

Compound 3, half-maximal inhibitory concentration: 1230 nM
The estimate for compound 3 lay 1.2-fold (0.09 log units) below the measured number, and the stated range covers the measured number.
By their numbers in this assay, from the lowest: compounds 2 and 3 (each within the scatter of the next); then compound 1.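

In this assay, 1H-benzimidazol-2-yl in place of 1,3,4-thiadiazol-2-yl on the sulfur gives a 1.1-fold higher number from compound 2 to compound 3 (0.03 log units; within the scatter), so the added six-membered aromatic ring of carbon only and the hydrogen-bond donor leave the number within the scatter. Against the non-aromatic group of compound 1, the same group gives a 2.4-fold lower number from compound 1 to compound 3 (0.38 log units; beyond the scatter), so two different aromatic groups on this sulfur now stand apart from compound 1. No evidence on hand explains either step.

From the compounds shown here alone, whether an amine, a carboxylic acid or a plain alkyl chain on this sulfur would hold these numbers remains open.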